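From a Methoxyphenylsulfanyl Group to a Fluorophenoxy Group

The source may report more compounds than this note shows. Statements on the series, on what has been measured and on what is new or still open speak of the compounds shown alone.

Measured compounds:
compound 1, `Nc1cc(N)c2nc(-c3ccccc3)c(NCc3ccc(F)cc3)nc2c1`, < 100000 nM
compound 2, `COc1ccc(Sc2nc3cc(N)cc(N)c3nc2-c2ccccc2)cc1`, 4170 nM

In a functional assay on MOLT-4 cells (Homo sapiens) for inhibition, read by sulforhodamine B assay, with a stated time of 48 h (a lower number here means a stronger inhibitor of growth, a higher number a weaker inhibitor of growth), compound 1 `Nc1cc(N)c2nc(-c3ccccc3)c(NCc3ccc(F)cc3)nc2c1` gives < 100000 nM, which is a limit of the assay and not a number. Compound 2 `COc1ccc(Sc2nc3cc(N)cc(N)c3nc2-c2ccccc2)cc1` gives 4170 nM in this assay. The step that the limit leaves unreadable from compound 1 to compound 2 cannot be read, as the limit of < 100000 nM in this assay, at which 1 of the 2 values shown sits, shows. Among the measured compounds shown here, compound 2 therefore stands as the only numeric value in this assay, with nothing to rank it against.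

Compound 3 `Nc1cc(N)c2nc(-c3ccccc3)c(Oc3ccc(F)cc3)nc2c1` differs from compound 2 in one place: 4-fluorophenoxy in place of (4-methoxyphenyl)sulfanyl on an aromatic carbon. For the measured compounds named here, no measured step bears on this change; the single step between measured compounds is unreadable. The expectation is therefore a step no larger than the scatter, estimated as a 1.2-fold higher number from compound 2 to compound 3 (0.08 log units; within the scatter). For compound 3 the estimate in this assay is 5000 nM, expected to lie between 1500 nM and 20000 nM.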

Compound 3, concentration for 50% growth inhibition: 6610 nM
For compound 3 the middle estimate is 1.3-fold (0.12 log units) below the measured one, and the stated range covers the measured number.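

In this assay, among the compounds shown here, 4-fluorophenoxy in place of (4-methoxyphenyl)sulfanyl on this aromatic carbon gives a 1.6-fold higher number from compound 2 to compound 3 (0.20 log units; within the scatter), the first step at this position that can be read. The two groups differ both in the atom that links them to the core and in the group on their aromatic ring, and with both changed at once compound 2 and compound 3 cannot be told apart in this assay. The steps from compound 1 cannot be read, because its value is a limit of the assay and not a number: the limit of < 100000 nM in this assay, at which 1 of the 3 values shown sits.

The compounds shown leave open whether the linking atom and the group on the ring would each read the same alone, as a 4-methoxyphenoxy or a (4-fluorophenyl)sulfanyl group at this position would tell. As far as these compounds go, what a morpholine or a carboxylic acid would give on this carbon also stays open.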